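The compounds below may be only part of what the source reports. "The series", "measured", "known", "first", "only" and "open" are said of these compounds alone.

Compound 1 `Cc1noc(NS(=O)(=O)c2cccc3c(N4CCCC4=O)cccc23)c1C`: 130 nM
Compound 2 `Nc1ccc(S(=O)(=O)Nc2noc3c2CCCC3)cc1`: > 32000 nM
Compound 3 `Cc1noc(NC(=O)c2ccc(N)cc2)c1C`: > 32000 nM

For the measured compounds named here, in an assay on VSM-A10 cells for antagonist activity at Endothelin-1 receptor (Rattus norvegicus) (a higher number here means a weaker inhibitor, a lower number a stronger inhibitor), compound 1 gives 130 nM, the only real number among the three. Compound 2 reaches only the assay limit of > 32000 nM. Compound 3 likewise sits at the limit of > 32000 nM. Compound 1 therefore stands alone, the other two resting at the limit of > 32000 nM in this assay, at which 2 of the 3 values shown sit.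

Compound 4 `Cc1noc(NS(=O)(=O)c2cccc3c(C(C)(C)O)cccc23)c1C` has not yet been measured. It differs from compound 1 in one place: 1-hydroxy-1-methylethyl in place of 2-oxopyrrolidin-1-yl on an aromatic carbon. Both groups are uncharged and each carries one hydrogen-bond acceptor; the entering group also brings one hydrogen-bond donor. Going by the values given here, no measured step of this kind exists, so the expectation rests on compound 1 alone. The step of a 1.9-fold higher number from compound 1 to compound 4 (0.28 log units; within the scatter) is expected to be small, near the scatter. Compound 4 is thus estimated at 250 nM, within 60 nM to 1500 nM.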

Compound 4, half-maximal inhibitory concentration: 2890 nM
For compound 4 the middle estimate is 12-fold (1.06 log units) below the measured one, and the stated range ends below it.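

In this assay, placing 1-hydroxy-1-methylethyl instead of 2-oxopyrrolidin-1-yl on this aromatic carbon gives a 22-fold higher number from compound 1 to compound 4 (1.35 log units; beyond the scatter) and so shows that the group held here strongly affects the result. The change weakens inhibition without removing it, as compound 4 gives 2890 nM.

Nothing shown here explains the size of this step. Going by these compounds, it also remains open whether the ring, the carbonyl or the added hydroxyl drives the change, which an open-chain amide or a simple amine at this position could help separate.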